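Replacing the ester side chain of compound 2

This account rests on a few compounds, and the source may have more. Where it says the series, first, only, none or still open, it means among the compounds named here.

Measured so far in a functional assay on NALM-6 cells (Homo sapiens) for cytotoxicity, with a stated time of 72 h; a higher number here means that more compound is needed for the effect, a lower number that less compound is needed:
Compound 1 `C=C[C@@](C)(/C=C/c1ccc(O)c(C=O)c1)CCC=C(C)C`: 11200 nM
Compound 2 `C=C[C@@](C)(/C=C/c1ccc(O)c(/C=C(\C)C(=O)OCC)c1)CCC=C(C)C`: > 7500 nM (a limit)

Compound 2 is known only through a limit, > 7500 nM. This is the limit of > 7500 nM in this assay, at which 1 of the 2 values shown sits. Compound 3 `C=C[C@@](C)(/C=C/c1ccc(O)c(/C=C/c2ccc(Cl)cc2)c1)CCC=C(C)C` has 2-(4-chlorophenyl)ethenyl in place of 2-(ethoxycarbonyl)prop-1-en-1-yl on an aromatic carbon, ortho to a hydroxy group: 2-(4-chlorophenyl)ethenyl in place of 2-(ethoxycarbonyl)prop-1-en-1-yl on an aromatic carbon.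

For the measured compounds named here, only one measured step bears on this change: a step that the limit leaves unreadable from compound 1 to compound 2. It puts the departing group in place of formyl, but it offers no size to carry over and no direction. Going by the values given here, the only firm number is therefore that of compound 1, at 11200 nM.

No change beyond the scatter is expected in this assay, and the estimated step is a step that the limit leaves unreadable from compound 2 to compound 3. For compound 3 the expected value is 9000 nM, with an estimated range of 3000 nM to 25000 nM.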

Compound 3, half-maximal effective concentration: > 43400 nM
Compound 3 ended at the assay's limit (the forecaster's own chance of this, stated with the estimate: 35%); middle value at least 4.8-fold (0.68 log units) from the limit.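

Against the formyl group, 2-(4-chlorophenyl)ethenyl at this place, ortho to a hydroxy group, gives the first readable step in this assay: an at least 3.8-fold higher number from compound 1 to compound 3 (0.58 log units; beyond the scatter). Compound 3 is known only through a limit of the assay, not a number: the limit of > 43400 nM in this assay, at which 1 of the 3 values shown sits. The steps from compound 1 to compound 2 and from compound 2 to compound 3 cannot be read, and the ester side chain and the 2-(4-chlorophenyl)ethenyl group stay unranked against each other.

The compounds shown do not separate the part played by the chlorine from that of the added aromatic ring or the ethenyl link. From the compounds shown here alone, it also stays open whether a side chain ending in an amine or a carboxylic acid at this place would give a readable value.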